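A few compounds are considered here, and "the series" means these few. Any claim that something is new, unique, unknown or untested is made for them only; others in the source may bear on it.

Of the compounds shown here, three built on a shared core have been tested in an ADME assay on Huh-7 cells (Homo sapiens) for cytotoxicity, read by XTT assay, with a stated time of 3 days, tested at 20 uM; on this read-out higher numbers stand for a weaker effect at the one concentration tested and lower numbers for a stronger effect. Compound 1 `Fc1ccc(-c2cc(-c3ccc4cc(F)ccc4n3)n(-c3ccccc3)n2)cc1` gives 88.1% in this assay. Compound 2 `Fc1ccc(-c2cc(-c3ccc4cc(F)ccc4n3)n(-c3ccc(F)cc3)n2)cc1` differs from compound 1 in one place: fluoro in place of hydrogen on an aromatic carbon. In this assay compound 2 gives 95.3%, so that the change reads a number 7.2 percentage points higher from compound 1 to compound 2 (within the scatter). Compound 3 `NS(=O)(=O)c1ccc(-n2nc(-c3ccccc3)cc2-c2ccc3cc(F)ccc3n2)cc1` carries a different core; how the core of compound 3 differs from the core of compound 1 is not broken down here. In this assay compound 3 gives 89.2%, a number that sits within the scatter of both compound 1 and compound 2, so no order among the three can be drawn from these values.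

Compound 4 `NS(=O)(=O)c1ccc(-n2nc(-c3ccc(F)cc3)cc2-c2ccc3cc(F)ccc3n2)cc1` has not yet been measured. It differs from compound 3 in one place: fluoro in place of hydrogen on an aromatic carbon. Within the data shown here, this is the same change as the one from compound 1 to compound 2, in the same place on the ring, so the measured step is the nearest guide to what compound 4 may show. Because a number 7.2 percentage points higher from compound 1 to compound 2 (within the scatter) lay within the scatter, the step from compound 3 to compound 4 is expected to be small as well, estimated as a number 3.8 percentage points higher from compound 3 to compound 4 (within the scatter). On that basis compound 4 is expected to give about 93% in this assay, with a likely range from 83% to 100%, pending the measurement.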

Compound 4, a percentage reported as activity, at one concentration (the size of the read-out at that concentration, not a potency): 91.1%
For compound 4 the middle estimate is 1.9 percentage points above the measured one; the measured number falls inside the stated range.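

Carried from the core of compound 1 to the core of compound 3, the change from phenyl to 4-fluorophenyl gives steps in this assay that cannot be told apart: the same change on two cores in this assay, a number 7.2 percentage points higher (within the scatter) from compound 1 to compound 2 and a number 1.9 percentage points higher (within the scatter) from compound 3 to compound 4, 5.3 percentage points apart, within the scatter of two such steps

The new step reads a number 1.9 percentage points higher from compound 3 to compound 4 (within the scatter), and the two steps that bring in sulfamoyl, a number 4.2 percentage points lower from compound 2 to compound 4 (within the scatter) and a number 3 percentage points higher from compound 1 to compound 4 (within the scatter), likewise stay inside the scatter, so on these four compounds neither fluoro nor sulfamoyl on this aromatic carbon gives a step that can be told from repeated measurement. Among these compounds, this shows only that the change stays within the scatter on both cores; it does not show that fluoro has a real effect of the same size on each core, since neither step can be told from zero, and two pairs at one concentration cannot establish a rule for other cores.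

The compounds shown leave open whether a different group on the same aromatic carbon, such as an amine, a carboxylic acid or a longer alkyl chain, would give a step beyond the scatter. They also leave open whether chloro or methoxy in place of fluoro would behave as fluoro does on both cores.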